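A few compounds are considered here, and "the series" means these few. Any claim that something is new, unique, unknown or untested is made for them only; others in the source may bear on it.

Measured so far in an assay on Prostate gland for inhibition of steroid 5-alpha-reductase (Rattus norvegicus); a higher number here means a weaker inhibitor, a lower number a stronger inhibitor:
compound 1, `CCCC(C)n1ccc2cc(/C(C)=C/C(=O)Nc3ccccc3OCCCC(=O)O)ccc21`, gives 7.8 nM;
compound 2, `CCCCc1ccc(Cn2ccc3cc(/C(C)=C/C(=O)Nc4ccccc4OCCCC(=O)O)ccc32)cc1`, gives 100 nM;
compound 3, `CCCCC(c1ccccc1)n1ccc2cc(/C(C)=C/C(=O)Nc3ccccc3OCCCC(=O)O)ccc21`, gives 9.8 nM.

All three share the same core and differ only in the group carried on the aromatic nitrogen. Compound 3 sits close to compound 1 in this assay, the two being separated by a gap within the usual scatter, as the step of a 1.3-fold higher number from compound 1 to compound 3 (0.10 log units; within the scatter) shows. Compound 2 stands apart: the step of a 13-fold higher number from compound 1 to compound 2 (1.11 log units; beyond the scatter) and the step of a 10-fold lower number from compound 2 to compound 3 (1.01 log units; beyond the scatter) are both large, so the 4-butylbenzyl group on the nitrogen clearly weakens inhibition compared with either of the branched groups.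

Compound 4, `C/C(=C\C(=O)Nc1ccccc1OCCCC(=O)O)c1ccc2c(ccn2C(c2ccccc2)C(C)C)c1`, is not yet measured. It differs from compound 3 by isopropyl in place of butyl on a saturated chain carbon bound to an aromatic carbon and an aromatic nitrogen, so the phenyl on that branching carbon is kept and only the alkyl part shortens. The step that bears most on this change is a 1.3-fold higher number from compound 1 to compound 3 (0.10 log units; within the scatter), where a different alkyl branch beside the phenyl made no difference beyond the scatter. The two large steps involving compound 2 concern a different kind of group and say little here. The step of a 1.2-fold higher number from compound 3 to compound 4 (0.09 log units; within the scatter) is therefore expected to stay within the scatter. Compound 4 is estimated at 12 nM, with a range from 5 nM to 30 nM.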

Compound 4, half-maximal inhibitory concentration: 25 nM
Estimate against measurement, compound 4: 2.1-fold (0.32 log units) below; measured number inside the range.
By their numbers in this assay, from the lowest: compounds 1 and 3 (each within the scatter of the next); then compound 4; then compound 2.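

In this assay the alkyl part of the group on the aromatic nitrogen matters even when the phenyl stays: isopropyl in place of butyl on that saturated chain carbon gives a 2.6-fold higher number from compound 3 to compound 4 (0.41 log units; beyond the scatter) as a modest loss, something not seen earlier, when compounds with 1-methylbutyl and 1-phenylpentyl on the nitrogen fell within the scatter of each other. The new 2-methyl-1-phenylpropyl group also separates from 1-methylbutyl, with a 3.2-fold higher number from compound 1 to compound 4 (0.51 log units; beyond the scatter) marking a modest gap, yet it still does better than 4-butylbenzyl, with a 4.0-fold lower number from compound 2 to compound 4 (0.60 log units; beyond the scatter) as the step. Compound 4 therefore forms a middle level of its own, and so the group on the nitrogen gives more than a simple split into good branched groups and one poor benzyl group, though no measurement available here accounts for this change.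

Open, on these data alone, is whether a straight propyl on that carbon would sit with compound 3 or with compound 4, a result that would separate chain length from branching. Equally open, as far as these compounds go, is how a cyclohexyl in place of the phenyl, or an amine carried on the butyl, would read in this assay against these values.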